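The compounds below may be only part of what the source reports. "The series", "measured", "known", "first", "only" and "open" are said of these compounds alone.

Measured so far:
compound 1 `COc1cc(C)cc(-c2c(-c3ccnc(-c4ccc(C(C)=O)cc4)c3)cnn2CC#N)c1` – 102%
compound 2 `COc1cc(C)cc(-c2nn(CC#N)cc2-c2ccc(-c3cccc(C(C)=O)c3)nc2)c1` – 102%
compound 3 `Cc1cc(O)cc(-c2nn(CC#N)cc2-c2ccnc(-c3ccc(Oc4ccccc4)cc3)c2)c1` – 100%

In a functional assay on SNB-19 cells (Homo sapiens) for cytotoxicity, read by sulforhodamine B assay, with a stated time of 48 h, tested at 0.01 uM (a lower number here means a stronger effect, a higher number a weaker effect of the compound at the concentration tested), compound 1 gives 102%, the same number at the digits reported as compound 2 with 102%, and the gap to compound 3 at 100% is within the scatter. At this concentration the three numbers do not separate; none of the compounds shows a measurable effect.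

Compound 4 `COc1cc(C)cc(-c2c(-c3ccnc(-c4ccc(N(C)C)cc4)c3)cnn2CC#N)c1` follows from compound 1 by one change: dimethylamino in place of acetyl on an aromatic carbon. Among the measured compounds shown here, no measured pair carries this change. The expected step is none beyond the scatter, because compound 1 already stands at 102% with the other two level with it. Compound 4 is therefore estimated at 100%, within 92% to 108%. That estimate means an expected step of a number 2 percentage points lower from compound 1 to compound 4 (within the scatter).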

Compound 4, a percentage reported as activity, at one concentration (the size of the read-out at that concentration, not a potency): 44%
The estimate for compound 4 lay 56 percentage points above the measured number; the measured number lies below the stated range.
By their numbers in this assay, from the lowest: compound 4; then compounds 3, 1 and 2 (each within the scatter of the next).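

Dimethylamino in place of acetyl on an aromatic carbon, para to a large group, gives in this assay a number 58 percentage points lower from compound 1 to compound 4 (beyond the scatter). Among the compounds shown here, the substituent at this position can therefore move the read-out at this concentration, which the earlier compounds, with no separation among them, did not show. No measurement at hand bears on why the step arises.

Going by these compounds, whether the step is specific to dimethylamino remains open: a primary amine, a pyrrolidine or a methoxy group at the same place would test this. On these data alone, the effect of the same exchange on other cores also remains open.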